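A few compounds are considered here, and "the series" means these few. Any claim that something is new, unique, unknown or untested is made for them only; others in the source may bear on it.

Measured compounds:
compound 1 `CS(=O)(=O)c1nn(Cc2nc3cc(Cl)ccc3n2CCCO)c2cnccc12` — > 100000 nM (a limit of the assay)
compound 2 `CC(C)(O)CCn1c(Cn2nc(S(C)(=O)=O)c3ccncc32)nc2cc(Cl)ccc21` — > 100000 nM (a limit of the assay)
compound 3 `CS(=O)(=O)c1nn(Cc2nc3cc(Cl)ccc3n2CCOCCO)c2cnccc12` — > 100000 nM (a limit of the assay)

The three measured compounds share one core and differ only at a saturated chain carbon, two bonds along the chain from an aromatic nitrogen. In an ADME assay on HEp-2 cells (Homo sapiens) for cytotoxicity, with a stated time of 4 days (on this read-out higher numbers stand for lower toxicity in this test and lower numbers for higher toxicity in this test), compound 1 gives > 100000 nM, which is a limit of the assay and not a number. Compound 2 also gives only a limit, > 100000 nM. Compound 3 stands at a limit as well, > 100000 nM. Because all three sit at the limit of > 100000 nM in this assay, at which 3 of the 3 values shown sit, none of the steps among them can be read: a step that the two limits leave unreadable from compound 1 to compound 2, a step that the two limits leave unreadable from compound 1 to compound 3 and a step that the two limits leave unreadable from compound 2 to compound 3 all remain of unknown size.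

Compound 4 `CS(=O)(=O)c1nn(Cc2nc3cc(Cl)ccc3n2CCCCC(F)(F)F)c2cnccc12` has not yet been measured. It differs from compound 3 by 3,3,3-trifluoropropyl in place of 2-hydroxyethoxy on a saturated chain carbon, two bonds along the chain from an aromatic nitrogen. Within the data shown here, no measured step bears on this change with a readable size, so neither a direction nor a size can be drawn from them; what the data do show is that three different chains at this position all reached the limit. Compound 4 is therefore expected to lie near that same limit, and the step of a number no higher from compound 3 to compound 4 (the limit leaves the size open) is expected to be small, with wide uncertainty. The estimate for compound 4 is 100000 nM, within 20000 nM to 300000 nM.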

Compound 4, half-maximal cytotoxic concentration: > 100000 nM
Compound 4: only a limit was reported (the forecaster's own chance of this, stated with the estimate: 60%); the middle value sits exactly at the limit.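

In this assay compound 4 gives > 100000 nM, which is a limit of the assay and not a number. Its steps from compound 1, compound 2 and compound 3 cannot be read, because all four compounds share one limit: the limit of > 100000 nM in this assay, at which 4 of the 4 values shown sit.

The compounds shown leave open whether these four chains differ in toxicity at all in this assay, and by how much.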